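Replacing a Tetrazole with Piperidine on the Shared Core

The compounds below may be only part of what the source reports. "The series", "measured", "known", "first", "only" and "open" are said of these compounds alone.

Measured compounds:
compound 1 `CCC(C)(C)Cc1c[nH]c(CCc2ccc(-n3ncnn3)cc2)n1`: 25 nM
compound 2 `CCC(C)(C)Cc1c[nH]c(CCc2ccc(-n3ccnn3)cc2)n1`: 57 nM

In a functional assay on HEK293 cells for agonist activity at Bombesin receptor subtype-3 (Mus musculus), read by luminescence and calcium flux, with a stated time of 10 min (a higher number here means that more compound is needed for the effect, a lower number that less compound is needed), compound 1 gives 25 nM, the lowest of the two numbers. Among the compounds with values here, the only measured step is a 2.3-fold higher number from compound 1 to compound 2 (0.36 log units; beyond the scatter), where one small aromatic ring replaced another. Compound 3 `CCC(C)(C)Cc1c[nH]c(CCc2ccc(N3CCCCC3)cc2)n1` is not yet measured. It differs from compound 1 by piperidin-1-yl in place of 2H-tetrazol-2-yl on an aromatic carbon. Within the data shown here, no measured step exchanges the tetrazole for a non-aromatic ring, so the known step bears on it only loosely, and the direction of change is uncertain. A modest step toward a higher number is expected, a 3.2-fold higher number from compound 1 to compound 3 (0.51 log units; beyond the scatter). Compound 3 is therefore estimated at 80 nM, within 15 nM to 500 nM.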

Compound 3, half-maximal effective concentration: 28 nM
Estimate against measurement, compound 3: 2.9-fold (0.46 log units) above; the measured number falls inside the stated range.
By their numbers in this assay, from the lowest: compounds 1 and 3 (each within the scatter of the next); then compound 2.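

Exchanging 2H-tetrazol-2-yl for piperidin-1-yl, a non-aromatic ring with 1 hydrogen-bond acceptor instead of 4, gives a 1.1-fold higher number from compound 1 to compound 3 (0.05 log units; within the scatter) and so no real change, which shows that an aromatic ring is not required at this position. The same group gives a 2.0-fold lower number from compound 2 to compound 3 (0.31 log units; beyond the scatter) when it replaces 1H-1,2,3-triazol-1-yl, so neither aromatic ring holds an advantage over it here. Nothing available explains these results. On these data alone, whether an open-chain amine, a carboxylic acid or a morpholine ring would keep the number this low remains open.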